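The source may report more compounds than this note shows. Statements on the series, on what has been measured and on what is new or still open speak of the compounds shown alone.

Measured so far:
compound 1 `CN(C)CCN(CCN(C)C)c1ccc(C(=O)N2CCc3ccc(OS(N)(=O)=O)cc3C2)cc1` — 3.8%
compound 2 `NS(=O)(=O)Oc1ccc2c(c1)CN(C(=O)c1ccc(N(Cc3ccccc3)Cc3ccco3)cc1)CC2` — 90.8%

In an assay on HEK293 cells for inhibition of Steryl-sulfatase (Homo sapiens), tested at 0.1 uM (a higher number here means a stronger effect of the compound at the concentration tested, a lower number a weaker effect), compound 1 gives 3.8%, the lower of the two numbers; compound 2 stands far above it, beyond the scatter. Compound 3 `CCN(Cc1ccc(F)cc1)c1ccc(C(=O)N2CCc3ccc(OS(N)(=O)=O)cc3C2)cc1` is not yet measured. Against compound 1 the change is ethyl(4-fluorobenzyl)amino in place of bis(2-(dimethylamino)ethyl)amino on an aromatic carbon. For the measured compounds named here, no step between measured compounds is available to calibrate it. Compound 2 carries a benzyl group on the same nitrogen and gives 90.8%. On that basis the step is expected to be a rise well beyond the scatter: a number 76.2 percentage points higher from compound 1 to compound 3 (beyond the scatter). Compound 3 is estimated at 80%, in the range 55% to 97%.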

Compound 3, a percentage reported as inhibition, at one concentration (the size of the read-out at that concentration, not a potency): 69.1%
Estimate against measurement, compound 3: 10.9 percentage points above, within the range that was stated.
By their numbers in this assay, from the lowest: compound 1; then compound 3; then compound 2.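

The step of a number 65.3 percentage points higher from compound 1 to compound 3 (beyond the scatter) in this assay shows that this position, para to a large group, responds strongly to the choice of amine substituent. Ethyl(4-fluorobenzyl)amino and bis(2-(dimethylamino)ethyl)amino both count 11 heavy atoms, so heavy-atom count does not separate them, whereas the aromatic ring, the fluorine and the number of nitrogens do differ. No measurement shown bears on the origin of this step.

Open, as far as these compounds go, is which of these differences carries the step. Ethyl(benzyl)amino, without the fluorine, and (2-(dimethylamino)ethyl)(4-fluorobenzyl)amino would help to separate them.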